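The source may hold more compounds than are shown below. What is called first, only, known or untested is meant among the compounds shown, and "the series" means these compounds.

Three analogues share one core and differ only in the aryl group on the amide nitrogen. Compound 1 `O=C(COc1ccc2cc(/C=C3/SC(=O)NC3=O)ccc2c1)Nc1ccccn1` gives 17000 nM in an assay on isolated protein for inhibition of histone deacetylase 4 (Homo sapiens), with a stated time of 1 h; on this read-out higher numbers stand for weaker inhibition and lower numbers for stronger inhibition. Compound 2 `O=C(COc1ccc2cc(/C=C3/SC(=O)NC3=O)ccc2c1)Nc1ccccc1` gives 2100 nM in this assay, the lowest number of the three, while compound 3 `COc1ccc(NC(=O)COc2ccc3cc(/C=C4/SC(=O)NC4=O)ccc3c2)cc1` gives 4700 nM. Within the data shown here, the steps of an 8.1-fold lower number from compound 1 to compound 2 (0.91 log units; beyond the scatter) and a 3.6-fold lower number from compound 1 to compound 3 (0.56 log units; beyond the scatter) lower the number, whereas the step of a 2.2-fold higher number from compound 2 to compound 3 (0.35 log units; beyond the scatter) raises it, and that last step is the only one in which a group is added to the phenyl. Compound 4 `O=C(COc1ccc2cc(/C=C3/SC(=O)NC3=O)ccc2c1)Nc1ccccc1Oc1ccccc1` arises from compound 2 by phenoxy in place of hydrogen on an aromatic carbon. For compound 4 a modest rise in this assay is therefore expected, a 2.1-fold higher number from compound 2 to compound 4 (0.33 log units; beyond the scatter). Compound 4 is estimated at 4500 nM, within 1500 nM to 14000 nM.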

Compound 4, half-maximal inhibitory concentration: 5200 nM
Compound 4: the middle estimate sits 1.2-fold (0.06 log units) below what was measured; the range from low to high includes it.
By their numbers in this assay, from the lowest: compound 2; then compounds 3 and 4 (each within the scatter of the next); then compound 1.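

Placing phenoxy on an aromatic carbon ortho to a large group gives a 2.5-fold higher number from compound 2 to compound 4 (0.39 log units; beyond the scatter) in this assay, so a substituent with its own six-membered aromatic ring of carbon only also raises the number, and the step remains modest. Both groups added to the phenyl of compound 2, methoxy in compound 3 and phenoxy in compound 4, raise the number, and neither lowers it. Nothing available explains this step. The compounds shown leave open whether a smaller group such as methyl or an amine on this same carbon would also raise the number. They also leave open whether a carboxylic acid there would lower it.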